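Adding Bromo to the Fused Ring of Compound 2

The compounds below may be only part of what the source reports. "The series", "measured", "known", "first", "only" and "open" are said of these compounds alone.

Measured compounds:
compound 1 `Cc1ccc(NCc2nc3ccc(Br)cc3[nH]2)cc1`: 16.6%
compound 2 `Clc1cccc(NCc2nc3ccccc3[nH]2)c1`: 44.4%
compound 3 `c1ccc(NCc2nc3ccccc3[nH]2)cc1`: 38.8%

In a functional assay on the whole organism (strain albino) for inhibition, with Rattus norvegicus as the target, read by paw edema, with a stated time of 180 min, at a dose of 100 mg/kg by the oral route (on this read-out lower numbers stand for less inhibition and higher numbers for more inhibition at the one dose given (going by the name of the read-out)), compound 2 gives 44.4%, the largest of the three numbers, but compound 3 lies within the usual scatter of it, so the two cannot be told apart; compound 1 lies well below both. For the measured compounds named here, the one single-point step among the measured compounds, a number 5.6 percentage points lower from compound 2 to compound 3 (within the scatter), concerns the chloro group and says nothing about bromo.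

Compound 4 `Clc1cccc(NCc2nc3ccc(Br)cc3[nH]2)c1` is compound 2 with a bromo added: bromo in place of hydrogen on an aromatic carbon. Going by the values given here, no measured pair isolates this change. Among the compounds with values here, the only hint is compound 1, which carries a bromo on its fused ring together with a methyl group and gives 16.6%, far below compound 3 at 38.8%; two groups differ there, so the bromo alone cannot be read off. A drop is therefore expected, but with wide uncertainty: compound 4 is estimated to show a number 14.4 percentage points lower from compound 2 to compound 4 (beyond the scatter). For compound 4 the expected value is 30%, in a range from 12% to 48%.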

Compound 4, a percentage reported as inhibition, in the whole organism at one dose (the size of the read-out at that dose, not a potency): 16.6%
Estimate against measurement, compound 4: 13.4 percentage points above; low and high end bracket the measured number.
By their numbers in this assay, from the lowest: compounds 1 and 4 (each within the scatter of the next); then compounds 3 and 2 (each within the scatter of the next).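

In this assay, bromo in place of hydrogen on an aromatic carbon of the fused system gives a number 27.8 percentage points lower from compound 2 to compound 4 (beyond the scatter). For the compounds shown here, this is the first single change here to stand clear of the scatter: the earlier step, a number 5.6 percentage points lower from compound 2 to compound 3 (within the scatter), did not, so this position on the six-membered aromatic ring of carbon only matters at this dose, and one added bromine atom is enough to show it. Nothing available explains why the number falls.

The compounds shown leave open whether the fall belongs to bromo alone or would also follow fluoro, a methoxy group or an amine on the same carbon. They also leave open whether the same change would lower the number as far on compound 3, which carries no chloro group.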